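This account rests on a few compounds, and the source may have more. Where it says the series, first, only, none or still open, it means among the compounds named here.

Compound 1 `COc1cccc2cc(C(=O)NCCO)c(=N)oc12` was tested in an assay on HEK293 cells for displacement of a labelled ligand from adenosine receptor A2b (Homo sapiens), read by scintillation counting, with a stated time of 30 min, tested at 10 uM (a lower number here means less inhibition, a higher number more inhibition at the concentration tested (going by the name of the read-out)), where compound 1 gives 65%. For the measured compounds named here, this is the higher of the two numbers measured so far. The other measured compound, compound 2 `COCCNC(=O)c1cc2cccc(OC)c2oc1=O`, differs from compound 1 in more than one place, and in this assay compound 2 gives 18%; the two values lie far apart, beyond the usual scatter of such measurements.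

The next compound, compound 3 `COc1cccc2cc(C(=O)NC3CCCCC3)c(=N)oc12`, keeps the core of compound 1 and changes only the group on the amide-type nitrogen: cyclohexyl in place of 2-hydroxyethyl on an amide-type nitrogen. Going by the values given here, no measured pair shows what this kind of change does in this assay, so the expectation rests on compound 1 alone. The step is expected to be small, likely a modest fall or none beyond the scatter, which is the meaning of a number 10 percentage points lower from compound 1 to compound 3 (within the scatter). Compound 3 is therefore estimated at 55%, with a range from 30% to 80%.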

Compound 3, a percentage reported as inhibition, at one concentration (the size of the read-out at that concentration, not a potency): > 70%
Compound 3 gave a limit, no number (the forecaster's own chance of this, stated with the estimate: 0%); middle value at least 15 percentage points from the limit.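

In this assay, the reading for compound 3 is a limit of the assay and not a number: the limit of > 70% in this assay, at which 1 of the 3 values shown sits. Placing cyclohexyl on the amide-type nitrogen in place of 2-hydroxyethyl gives a number at least 5 percentage points higher from compound 1 to compound 3 (that floor lies within the scatter), so the real size of the step remains unknown, and only its floor can be read. Even so, this position accepts a larger all-carbon ring with no hydrogen-bond donor or acceptor, with no loss of inhibition in this read-out, something no earlier pair could show.

Still open, from the compounds shown here alone, is how other groups on this nitrogen would behave, such as a small methyl, a flat phenyl ring, or a longer chain ending in an amine or a carboxylic acid. Also open, going by these compounds, is whether cyclohexyl would have the same effect on a different core.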